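From compound 2 to compound 4: methyl on nitrogen

The source may hold more compounds than are shown below. What is called first, only, known or untested is meant among the compounds shown, and "the series" means these compounds.

In a functional assay on TSGH cells (Homo sapiens) for inhibition, with a stated time of 72 h (on this read-out higher numbers stand for weaker inhibition and lower numbers for stronger inhibition), compound 1 `COc1cc(C(=O)n2ccc3ccccc32)cc(OC)c1OC` gives 8400 nM, compound 2 `COc1cc(C(=O)c2cccc3[nH]ccc23)cc(OC)c1OC` gives 54.4 nM and compound 3 `COc1cc(C(=O)c2ccc3[nH]ccc3c2)cc(OC)c1OC` gives 103 nM. Compound 2 therefore stands level with compound 3 within the scatter, and the numbers of both lie far under that of compound 1, beyond the scatter. Compound 4 `COc1cc(C(=O)c2cccc3c2ccn3C)cc(OC)c1OC` carries methyl in place of hydrogen on an aromatic nitrogen, (methyl in place of hydrogen on an aromatic nitrogen). Going by the values given here, no measured pair isolates this change, so the data offer no direct guide to its size. In this assay, no shift beyond the scatter is expected in either direction. The estimated move is a 1.2-fold lower number from compound 2 to compound 4 (0.08 log units; within the scatter). Compound 4 is expected at 45 nM, with an estimated range of 15 nM to 150 nM.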

Compound 4, half-maximal inhibitory concentration: 26.9 nM
Beside the measured number, compound 4's estimate is 1.7-fold (0.22 log units) above it; the range from low to high includes it.
By their numbers in this assay, from the lowest: compound 4; then compounds 2 and 3 (each within the scatter of the next); then compound 1.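

In this assay, methyl in place of hydrogen on the aromatic nitrogen gives a 2.0-fold lower number from compound 2 to compound 4 (0.31 log units; beyond the scatter) as a modest step, so the hydrogen on this nitrogen is not required for inhibition in this pair. Going by these compounds alone, this is the first measured pair that isolates a change at this position. No available evidence explains the step. As far as these compounds go, whether an ethyl group, a longer chain or an acetyl group on this nitrogen would extend the step remains open. Also open, from the compounds shown here alone, is whether methyl on the nitrogen of compound 3 would give a similar step.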